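Chromenyl chalcones: a thiophene in place of fluorophenyl

A few compounds are considered here, and "the series" means these few. Any claim that something is new, unique, unknown or untested is made for them only; others in the source may bear on it.

Measured compounds:
compound 1, `COc1ccc(C(=O)/C=C/c2cc(OC)c(OC)c(OC)c2)c2c1C=CC(C)(C)O2`, > 10000 nM in a functional assay on K562 cells (Homo sapiens) for antiproliferative activity, read by MTT assay, with a stated time of 24 h; on this read-out lower numbers stand for stronger inhibition and higher numbers for weaker inhibition
compound 2, `COc1ccc(C(=O)/C=C/c2ccc(F)cc2)c2c1C=CC(C)(C)O2`, > 10000 nM in this assay
compound 3, `COc1ccc(C(=O)/C=C/c2cccc3ccccc23)c2c1C=CC(C)(C)O2`, > 10000 nM in this assay

Three compounds share the core of compound 1 and differ only in the aryl group on the double-bonded chain. In this assay compound 1 reaches only the limit of > 10000 nM, not a number. Compound 2 gives the same kind of result in this assay, a limit of > 10000 nM. Compound 3 also stops at a limit, > 10000 nM, in this assay. So compound 2 stands where every compound here stands: no number is known for it, only (the limit of > 10000 nM in this assay, at which 3 of the 3 values shown sit).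

Compound 4, `COc1ccc(C(=O)/C=C/c2cccs2)c2c1C=CC(C)(C)O2`, has not yet been measured. It differs from compound 2 by thiophen-2-yl in place of 4-fluorophenyl on a double-bonded chain carbon bound to a double-bonded chain carbon. No measured step between any two of these compounds exists, since all three sit at the limit. With nothing pointing to a gain, the step from compound 2 is expected to be none beyond the scatter, a step that the limit leaves unreadable from compound 2 to compound 4, and a further limit is the most likely outcome. For compound 4 the estimated value in this assay is 12000 nM, within a range from 3000 nM to 40000 nM.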

Compound 4, half-maximal inhibitory concentration: > 10000 nM
Compound 4: a limit, no number; the forecaster's own chance of this, stated with the estimate: 80%; the middle value does not contradict the limit.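

Compound 4, like compound 2, gives a limit rather than a number in this assay, so no step can be read between these two compounds: the limit of > 10000 nM in this assay, at which 4 of the 4 values shown sit.

The compounds shown leave open what the actual values of compound 1, compound 2, compound 3 and compound 4 are, and whether any aryl group on the shared core would give a number in this assay.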